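The source may hold more compounds than are shown below. What is called first, only, known or untested is meant among the compounds shown, and "the series" means these compounds.

Of the compounds shown here, two have been measured so far in a functional assay on NRK-49F cells (Rattus norvegicus) for cytotoxicity, read by MTT assay, with a stated time of 24 h; a lower number here means a stronger inhibitor, a higher number a weaker inhibitor. Compound 1 (`COc1cc(/C=C(\C#N)C(=O)N/N=C(\C)c2c(O)c3ccc(O)cc3oc2=O)ccc1O`) gives 55400 nM and compound 2 (`C/C(=N\NC(=O)/C(C#N)=C/c1ccc(N(C)C)cc1)c1c(O)c2ccc(O)cc2oc1=O`) gives 53400 nM, so compound 2 stands level with compound 1 within the scatter. Compound 3 (`C/C(=N\NC(=O)/C(C#N)=C/c1ccc([N+](=O)[O-])cc1)c1c(O)c2ccc(O)cc2oc1=O`) keeps the rest of compound 2 and alters one group: nitro in place of dimethylamino on an aromatic carbon. The nitro group of compound 3 thus takes over the spot that dimethylamino holds in compound 2, para to a large group.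

Among the measured compounds shown here, only one measured step bears on this change. Putting 4-(dimethylamino)phenyl in place of 4-hydroxy-3-methoxyphenyl gave a 1.0-fold lower number from compound 1 to compound 2 (0.02 log units; within the scatter). For the measured compounds named here, no measured compound carries nitro, so this single step offers only limited guidance. Even so, it is the sole evidence available, and it shows no response in this assay to a change of this group. No step beyond the scatter is therefore expected in either direction, with the value of compound 2, 53400 nM, as the anchor. The expected result is a 1.1-fold lower number from compound 2 to compound 3 (0.05 log units; within the scatter). In this assay, the estimated value for compound 3 is 48000 nM, with an expected range of 21000 nM to 100000 nM.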

Compound 3, half-maximal inhibitory concentration: 43200 nM
Compound 3: middle estimate off by 1.1-fold (0.05 log units), on the high side; the range from low to high includes it.
By their numbers in this assay, from the lowest: compounds 3, 2 and 1 (each within the scatter of the next).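

In this assay, nitro in place of dimethylamino on an aromatic carbon, para to a large group, gives a 1.2-fold lower number from compound 2 to compound 3 (0.09 log units; within the scatter), so this position shows no response to a swap between two groups that match in heavy-atom count but differ in their atoms, with nitro also bringing a double bond outside aromatic rings. Compared with the 4-hydroxy-3-methoxyphenyl of compound 1, 4-nitrophenyl gives a 1.3-fold lower number from compound 1 to compound 3 (0.11 log units; within the scatter), which means that all three phenyl groups on this double-bonded chain carbon now stand level within the scatter, where earlier only two could be compared. Nothing at hand accounts for this flat response.

The compounds shown leave open whether a carboxylic acid, an amine or a longer chain on the same aromatic carbon would produce a step beyond the scatter. They also leave open whether the numbers in this assay would shift with a change in the shared core, such as an amine in place of one of its hydroxyl groups.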